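A few compounds are considered here, and "the series" means these few. Any claim that something is new, unique, unknown or untested is made for them only; others in the source may bear on it.

Measured compounds:
- Compound 1 `C#CCSc1nc(Sc2nnnn2CCN(C)C)c(C#N)c(-c2ccc(Cl)cc2)n1`: 6560 nM
- Compound 2 `C#CCSc1nc(Sc2nc(C)c(C)s2)c(C#N)c(-c2cc(OC)c(OC)c(OC)c2)n1`: > 20000 nM (a limit)
- Compound 3 `C#CCSc1nc(Sc2nccs2)c(C#N)c(-c2ccc(Cl)cc2)n1`: 5350 nM

Among the compounds with values here, in a functional assay on KYSE-70 cells for antiproliferative activity against KYSE-70 cell line (Homo sapiens), read by MTT assay, with a stated time of 72 h (on this read-out lower numbers stand for stronger inhibition and higher numbers for weaker inhibition), compound 1 gives 6560 nM, one of only two true numbers in this small set. The other belongs to compound 3, at 5350 nM. Compound 2 gives > 20000 nM, which is a limit of the assay and not a number.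

Compound 4 `C#CCSc1nc(Sc2nnnn2CCN(C)C)c(C#N)c(-c2cccc(Cl)c2)n1` keeps the same atoms as compound 1, joined differently: 3-chlorophenyl in place of 4-chlorophenyl on an aromatic carbon. In words, 3-chlorophenyl stands in place of 4-chlorophenyl on an aromatic carbon.

Within the data shown here, no measured step moves the chlorine, so the evidence is only indirect. Among the measured compounds shown here, the one step available changes a different group, on a sulfur, and gives a 1.2-fold lower number from compound 1 to compound 3 (0.09 log units; within the scatter). Compound 2 differs from compound 1 in more than one place, so it offers no clean comparison.

With so little to go on, no direction can be favoured, and no change beyond the scatter is expected. The expected step is a 1.0-fold lower number from compound 1 to compound 4 (0.00 log units; within the scatter).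

The estimated value for compound 4 is 6500 nM, with an expected range of 2800 nM to 15000 nM.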

Compound 4, half-maximal inhibitory concentration: 5320 nM
For compound 4 the middle estimate is 1.2-fold (0.09 log units) above the measured one, within the range that was stated.
By their numbers in this assay, from the lowest: compounds 4, 3 and 1 (each within the scatter of the next). At a limit, above all of these: compound 2.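

In this assay, within the data shown here, the swap of 4-chlorophenyl for 3-chlorophenyl gives a 1.2-fold lower number from compound 1 to compound 4 (0.09 log units; within the scatter) and is the first direct look at this position, since the earlier step changed only the group on a sulfur. Among these compounds, the two chlorine placements on the phenyl ring are therefore not told apart in this assay, although only this single pair speaks to the point. Nothing measured here explains why the number stays within the scatter.

Still open, on these data alone, is whether this position stays as undemanding with other groups, such as an amine or a carboxylic acid on the phenyl ring in place of the chlorine. As far as these compounds go, it is also open whether the same shift of the chlorine would behave alike with the 1,3-thiazol-2-yl group of compound 3 on the sulfur.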